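This account rests on a few compounds, and the source may have more. Where it says the series, first, only, none or still open, it means among the compounds named here.

Measured compounds:
compound 1, `COc1cc(CC(O)(COCc2ccccc2)COCc2ccccc2)nc(OC)n1`, > 100000 nM
compound 2, `COc1nc(CC(O)(COCc2ccccc2)COCc2ccccc2)c(C)c(OC)n1`, 6100 nM
compound 3, `COCn1c(CC(COCc2ccccc2)COCc2ccccc2)cc(=O)[nH]c1=O`, > 100000 nM

In a functional assay on MIA PaCa-2 cells (Homo sapiens) for antiproliferative activity, read by MTT assay, with a stated time of 72 h (on this read-out higher numbers stand for weaker inhibition and lower numbers for stronger inhibition), compound 1 gives > 100000 nM, which is a limit of the assay and not a number. Compound 2 gives 6100 nM. The change between the two is methyl in place of hydrogen on an aromatic carbon, and the step it made is an at least 16-fold lower number from compound 1 to compound 2 (1.21 log units; beyond the scatter). Compound 3 gives > 100000 nM, again a limit. How the core of compound 3 differs from the core of compound 1 is not broken down here. Compound 4, `COCn1c(CC(COCc2ccccc2)COCc2ccccc2)c(C)c(=O)[nH]c1=O`, is not yet measured; it carries the same kind of change, (methyl in place of hydrogen on an aromatic carbon), though here the methyl sits ortho to a group of 1 heavy atom, meta to a methoxymethyl group and para to a group of 1 heavy atom, whereas in compound 2 it sits ortho to a methoxy group and para to a methoxy group. Resting on an at least 16-fold lower number from compound 1 to compound 2 (1.21 log units; beyond the scatter) and on compound 3 sitting at the limit of > 100000 nM in this assay, at which 2 of the 3 values shown sit, the step from compound 3 to compound 4 is expected to be an at least 6.6-fold lower number from compound 3 to compound 4 (0.82 log units; beyond the scatter), with wide uncertainty. Compound 4 is thus estimated at about 15000 nM, between 4000 nM and 100000 nM.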

Compound 4, half-maximal inhibitory concentration: 55900 nM
Compound 4: the middle estimate sits 3.7-fold (0.57 log units) below what was measured; the range from low to high includes it.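

In this assay, methyl in place of hydrogen on an aromatic carbon gives an at least 1.7-fold lower number from compound 3 to compound 4 (0.25 log units; that floor lies within the scatter). Compound 3 gives > 100000 nM, which is a limit of the assay and not a number. The large step seen on the core of compound 1 is therefore neither shown to repeat in size nor shown to shrink on the core of compound 3: the same change on two cores in this assay, an at least 16-fold lower number (1.21 log units; beyond the scatter) from compound 1 to compound 2 and an at least 1.7-fold lower number (0.25 log units; that floor lies within the scatter) from compound 3 to compound 4; the limit leaves it open whether they differ

The compounds shown leave open whether an ethyl group, a chlorine atom or an amine on that same aromatic carbon would lower the number as methyl does. They also leave open how large the methyl step is on a core whose starting value is a number and not a limit.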